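A Methyl Step Carried Over to a Piperidine Amide

This account rests on a few compounds, and the source may have more. Where it says the series, first, only, none or still open, it means among the compounds named here.

Compound 1 `N#C[C@@H]1CCCN1C(=O)[C@@H]1C[C@H](C(=O)N2CCOCC2)CN1` and compound 3 `N#C[C@@H]1CCCN1C(=O)[C@@H]1C[C@H](C(=O)N2CCCCC2)CN1` share a core that differs in one place: piperidin-1-yl in place of morpholin-4-yl on a carbonyl carbon. In an assay on the whole organism (plasma, strain Sprague-Dawley) for inhibition of Dipeptidyl peptidase 4 (Rattus norvegicus), with a stated time of 10 h, at a dose of 1 mg/kg by the oral route (a lower number here means less inhibition, a higher number more inhibition at the dose given (going by the name of the read-out)), compound 1 gives 44% and compound 3 gives 50%, and the pair shows a number 6 percentage points higher from compound 1 to compound 3 (within the scatter). Compound 2 `C[C@@H]1N[C@H](C(=O)N2CCC[C@H]2C#N)C[C@@H]1C(=O)N1CCOCC1` carries a further change on the core of compound 1: methyl in place of hydrogen on a saturated ring carbon. In this assay compound 2 gives 85%, so that a number 41 percentage points higher from compound 1 to compound 2 (beyond the scatter). Compound 4 `C[C@@H]1N[C@H](C(=O)N2CCC[C@H]2C#N)C[C@@H]1C(=O)N1CCCCC1` has not yet been measured. It stands to compound 3 as compound 2 stands to compound 1, with the same change: methyl in place of hydrogen on a saturated ring carbon. The two places are described in identical words, so the change is the same one, made once on each core, and it occurs twice among these compounds. The step from compound 3 to compound 4 in this assay is expected to be a number 35 percentage points higher from compound 3 to compound 4 (beyond the scatter), resting on the size seen in a number 41 percentage points higher from compound 1 to compound 2 (beyond the scatter) and on compound 3 starting from 50%, which leaves only limited room upward. Compound 4 is accordingly estimated at 85%, with a range from 65% to 97%.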

Compound 4, a percentage reported as inhibition, in the whole organism at one dose (the size of the read-out at that dose, not a potency): 81%
For compound 4 the middle estimate is 4 percentage points above the measured one, within the range that was stated.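

In this assay, methyl in place of hydrogen on a saturated ring carbon carries over from the core of compound 1 to the core of compound 3, with a number 31 percentage points higher from compound 3 to compound 4 (beyond the scatter), and the two steps do not differ: the same change on two cores in this assay, a number 41 percentage points higher (beyond the scatter) from compound 1 to compound 2 and a number 31 percentage points higher (beyond the scatter) from compound 3 to compound 4, 10 percentage points apart, within the scatter of two such steps. Piperidin-1-yl in place of morpholin-4-yl on a carbonyl carbon gives a number 4 percentage points lower from compound 2 to compound 4 (within the scatter), and this step likewise reads the same on both cores: the same change on two cores in this assay, a number 6 percentage points higher (within the scatter) from compound 1 to compound 3 and a number 4 percentage points lower (within the scatter) from compound 2 to compound 4, 10 percentage points apart, within the scatter of two such steps. Within these compounds the two changes therefore behave independently, but this does not show that the methyl step would carry over to any other core, and each value is a reading at a single dose, not a potency.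

The compounds shown leave open whether ethyl or cyclopropyl on that same ring carbon would give a step of similar size. They also leave open whether the methyl step would hold with another group on the carbonyl carbon, such as pyrrolidin-1-yl or dimethylamino.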